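The source may report more compounds than this note shows. Statements on the series, on what has been measured and on what is new or still open speak of the compounds shown alone.

Compound 1 `COc1ccc(-c2oc3c(CC=C(C)C)c(OCC(=O)O)cc(O)c3c(=O)c2OCC(=O)O)cc1` gives > 100000 nM in a functional assay on MCF7 cells (Homo sapiens) for cytotoxicity, read by MTT assay (a lower number here means a stronger inhibitor, a higher number a weaker inhibitor), which is a limit of the assay rather than a number.
Compound 2 `COc1ccc(-c2oc3c(CC=C(C)C)c(OC(C(=O)O)C(=O)O)cc(O)c3c(=O)c2OC(C(=O)O)C(=O)O)cc1` gives > 100000 nM in this assay, again a limit of the assay.
Compound 3 `COc1ccc(-c2oc3c(CC=C(C)C)c(OCCCOC(=O)CCC(=O)O)cc(O)c3c(=O)c2OCCCOC(=O)CCC(=O)O)cc1` gives > 100000 nM in this assay, again a limit of the assay.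

Compound 1 stands at the limit of > 100000 nM in this assay, at which 3 of the 3 values shown sit, with no number to place it more exactly. Compound 4 `COc1ccc(-c2oc3c(CC=C(C)C)c(OCC(=O)O)cc(O)c3c(=O)c2O)cc1` differs from compound 1 in one place: hydrogen in place of carboxymethyl on an oxygen on an aromatic ring. Among the compounds with values here, no measured pair differs in one place, so there is no measured step to lean on. The expected step from compound 1 to compound 4 in this assay is an at least 1.1-fold lower number from compound 1 to compound 4 (0.04 log units; that floor lies within the scatter), meaning no change beyond the scatter is expected. Compound 4 is therefore estimated at 90000 nM, in a range from 20000 nM to 400000 nM, most likely reported once more only as a limit.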

Compound 4, half-maximal inhibitory concentration: > 100000 nM
Compound 4: only a limit was reported; the forecaster's own chance of this, stated with the estimate: 70%; at least 1.1-fold (0.04 log units) between middle value and limit.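

No step can be read from compound 1 to compound 4, as both are reported only as a limit: the limit of > 100000 nM in this assay, at which 4 of the 4 values shown sit. The compounds shown leave open how large any real difference between them is in this assay.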